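Carboxymethyl on the amino nitrogen of compound 2

The compounds below may be only part of what the source reports. "The series", "measured", "known", "first", "only" and "open" are said of these compounds alone.

- compound 1 `COc1cc(OC)c(/C=C/S(=O)(=O)Nc2cc(N)c(OC)c(N)c2)c(OC)c1`: 2500 nM
- compound 2 `COc1cc(OC)c(/C=C/S(=O)(=O)Nc2ccc(OC)c(N)c2)c(OC)c1`: 5 nM
- compound 3 `COc1ccc(NS(=O)(=O)/C=C/c2c(OC)cc(OCCCC(=O)O)cc2OC)cc1N`: 10000 nM

In a functional assay on DU-145 cells (Homo sapiens) for cytotoxicity, read by trypan blue exclusion, with a stated time of 96 h (on this read-out higher numbers stand for weaker inhibition and lower numbers for stronger inhibition), compound 2 has the lowest number of the three at 5 nM. Compound 4 `COc1cc(OC)c(/C=C/S(=O)(=O)Nc2ccc(OC)c(NCC(=O)O)c2)c(OC)c1` has not yet been measured. It differs from compound 2 by carboxymethyl in place of hydrogen on a nitrogen on an aromatic ring, with carboxymethyl in place of hydrogen on a nitrogen on an aromatic ring.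

Within the data shown here, the closest precedent is the addition of 2-carboxyethyl, on a saturated chain carbon bound to an oxygen on an aromatic ring, which gave compound 3 in a 2000-fold higher number from compound 2 to compound 3 (3.30 log units; beyond the scatter). That change sits elsewhere on the molecule, so it is only a partial guide. The other measured step, a 500-fold lower number from compound 1 to compound 2 (2.70 log units; beyond the scatter), shows that compound 2 can lose much of its inhibition through one small change, but it involves no substitution on the nitrogen.

Among the measured compounds shown here, a large step toward weaker inhibition is therefore expected in this assay, though smaller than the one to compound 3. The expected step is an 80-fold higher number from compound 2 to compound 4 (1.90 log units; beyond the scatter). For compound 4 the estimated value is 400 nM, with an expected range from 30 nM to 5000 nM.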

Compound 4, half-maximal inhibitory concentration: 400 nM
Estimate against measurement, compound 4: no gap at the digits printed; the measured number falls inside the stated range.
By their numbers in this assay, from the lowest: compound 2; then compound 4; then compound 1; then compound 3.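

In this assay, among these compounds, carboxymethyl in place of hydrogen on the amino nitrogen gives an 80-fold higher number from compound 2 to compound 4 (1.90 log units; beyond the scatter), the first measured change at this nitrogen on an aromatic ring. The earlier steps shown here involved an aromatic carbon and a saturated chain carbon bound to an oxygen on an aromatic ring, so the large losses from compound 2 now extend to a third place on the molecule. Even so, compound 4 keeps a lower number than compound 2's other carboxylic acid analogue, compound 3, only across two changes, so that pair gives no clean comparison.

The compounds shown do not separate the effect of substitution on the nitrogen from that of the carboxylic acid: a methyl group, the methyl ester of the same chain or a longer chain ending in a carboxylic acid could do so. No measurement here explains the size of the step.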